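The source may report more compounds than this note shows. Statements on the series, on what has been measured and on what is new or still open speak of the compounds shown alone.

Measured so far:
- Compound 1 `O=C(CSc1nncnc1-c1cccc2ccccc12)Nc1ccccc1[N+](=O)[O-]`: 142000 nM
- Compound 2 `O=C(CSc1nncnc1-c1ccccc1Cl)c1ccc(Cl)c(Cl)c1`: 33000 nM

In an ADME assay on MT4 cells (Homo sapiens) for cytotoxicity, read by MTT assay (a higher number here means that more compound is tolerated, a lower number that less compound is tolerated), compound 1 stands highest of the two measured compounds, at 142000 nM. Compound 3 `Cc1ccc(NC(=O)CSc2nncnc2-c2cccc3ccccc23)c(Br)c1` has 2-bromo-4-methylphenyl in place of 2-nitrophenyl on an amide-type nitrogen. Going by the values given here, no measured pair isolates a single change, so the only guide is the lower reference, compound 2 at 33000 nM. A modest downward step in this assay is expected, estimated as a 2.4-fold lower number from compound 1 to compound 3 (0.37 log units; beyond the scatter). For compound 3 the estimated value is 60000 nM, with an expected range of 20000 nM to 180000 nM.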

Compound 3, half-maximal cytotoxic concentration: 166000 nM
Compound 3: middle estimate off by 2.8-fold (0.44 log units), on the low side; low and high end bracket the measured number.
By their numbers in this assay, from the lowest: compound 2; then compounds 1 and 3 (each within the scatter of the next).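

In this assay, 2-bromo-4-methylphenyl in place of 2-nitrophenyl on the amide-type nitrogen gives a 1.2-fold higher number from compound 1 to compound 3 (0.07 log units; within the scatter). This first single-place comparison shows that this position accepts the exchange with no difference beyond the scatter, so the 2-nitrophenyl group is not required to keep the number in this range. No measurement available speaks to why the two groups read alike.

From the compounds shown here alone, whether cyclohexyl, or a phenyl ring carrying a carboxylic acid, would read the same at this place remains open. Going by these compounds alone, compound 2 differs from the others in more than one place, so it gives no step here.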